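The compounds below may be only part of what the source reports. "The series", "measured", "known", "first", "only" and "open" are said of these compounds alone.

Measured compounds:
compound 1 `CCOc1ccc2nc(C)cc(OCC(=O)Nc3cc(C)cc(C)c3)c2c1` gives > 100000 nM
compound 2 `COc1ccc2nc(C)cc(OC3CCN(c4ccccc4)C3=O)c2c1` gives 100000 nM
compound 3 `COc1ccc2nc(C)cc(OCC(=O)Nc3cc(C)ccc3C)c2c1` gives > 100000 nM

All three values come from a toxicity assay on HepG2 cells (Homo sapiens) for inhibition, read by CellTiter-Glo, with a stated time of 48 h; on this read-out lower numbers stand for stronger inhibition and higher numbers for weaker inhibition. For compound 3 the value > 100000 nM is a limit of this assay, not a measured number. The same holds for compound 1, whose > 100000 nM is also a limit. Compound 2 gives 100000 nM in this assay, a number that sits at the very edge of the measured range. So compound 3 stands where most of the shown compounds stand, as told by the limit of > 100000 nM in this assay, at which 2 of the 3 values shown sit.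

Compound 4 `COc1ccc2nc(C)cc(OCC(=O)Nc3cc(C)nc(C)n3)c2c1` has not yet been tested in this assay. It differs from compound 3 in one place: 2,6-dimethylpyrimidin-4-yl in place of 2,5-dimethylphenyl on an amide-type nitrogen. No step between measured compounds is shown, so there is no measured guide to how this change acts on this read-out. Given that compound 3 sits at > 100000 nM and that the shown values cluster there, the step of a number no higher from compound 3 to compound 4 (the limit leaves the size open) is expected to stay within the usual scatter, with no clear direction. For compound 4 the estimate is 100000 nM, between 40000 nM and 300000 nM, most likely reported again as a limit of this assay.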

Compound 4, half-maximal inhibitory concentration: > 100000 nM
Compound 4: only a limit was reported; the forecaster's own chance of this, stated with the estimate: 75%; the middle value sits exactly at the limit.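

Compound 3 and compound 4 both stop at a limit of this assay rather than at a number, so no step can be read between them. The compounds shown leave open whether 2,6-dimethylpyrimidin-4-yl in place of 2,5-dimethylphenyl changes this read-out at all.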